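Removing the Chloro Group from a Diaryl Urea Pyrazole

This account rests on a few compounds, and the source may have more. Where it says the series, first, only, none or still open, it means among the compounds named here.

The measured compounds and their values:
Compound 1, `O=C(Nc1cccc(-n2cc(-c3ccncc3)c(-c3cc(O)cc(Cl)c3)n2)c1)Nc1ccc(Cl)c(C(F)(F)F)c1`, 34.3%
Compound 2, `COc1cc(Cl)cc(-c2nn(-c3cccc(NC(=O)Nc4ccc(Cl)c(C(F)(F)F)c4)c3)cc2-c2ccncc2)c1`, 18.1%
Compound 3, `COc1cc(Cl)cc(-c2nn(-c3cccc(NC(=O)Nc4cc(C(F)(F)F)cc(C(F)(F)F)c4)c3)cc2-c2ccncc2)c1`, 9.5%

In a functional assay on HCC 2998 cells (Homo sapiens) for inhibition, read by sulforhodamine B assay, with a stated time of 48 h, tested at 10 uM (a lower number here means a stronger effect, a higher number a weaker effect of the compound at the concentration tested), compound 2 gives 18.1%, the second highest of the three numbers. Its nearest neighbour is compound 3 with 9.5%, which lies within the scatter of compound 2; the furthest is compound 1 with 34.3%, beyond the scatter. For the measured compounds named here, the one step between compounds that differ in a single place is a number 16.2 percentage points lower from compound 1 to compound 2 (beyond the scatter), a modest step.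

Compound 4 is `COc1cc(Cl)cc(-c2nn(-c3cccc(NC(=O)Nc4cccc(C(F)(F)F)c4)c3)cc2-c2ccncc2)c1`. It differs from compound 2 in one place: hydrogen in place of chloro on an aromatic carbon. Going by the values given here, no measured step concerns the chloro group, so the step from compound 1 to compound 2 does not bear on this change. The pair compound 2 and compound 3 shows that varying the groups on the same aromatic ring has moved the number only within the scatter. Compound 4 is therefore expected to stay close to compound 2 in this assay, with an expected step of a number 3.9 percentage points higher from compound 2 to compound 4 (within the scatter), not beyond the scatter. The estimate for compound 4 is 22%, with a range from 10% to 40%.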

Compound 4, a percentage reported as activity, at one concentration (the size of the read-out at that concentration, not a potency): 19%
The estimate for compound 4 lay 3 percentage points above the measured number, within the range that was stated.
By their numbers in this assay, from the lowest: compounds 3, 2 and 4 (each within the scatter of the next); then compound 1.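

In this assay the chloro group proves dispensable at this place, para to a large group: going from 4-chloro-3-(trifluoromethyl)phenyl to 3-(trifluoromethyl)phenyl gives a number 0.9 percentage points higher from compound 2 to compound 4 (within the scatter) and so leaves the number where it was. The earlier compounds shown here held no step at this position, and the new one adds a second reading on the same ring, where trading trifluoromethyl for hydrogen gives a number 9.5 percentage points higher from compound 3 to compound 4 (within the scatter) and also stays inside the usual variation. Nothing measured here explains why this ring tolerates both changes.

The compounds shown leave open whether an amine or a carboxylic acid at this place would keep the number as close as hydrogen and chloro do. They also leave open how the ring would behave with its remaining trifluoromethyl group replaced by hydrogen as well.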